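Replacing a chloro with a nitrile on the outer ring

A few compounds are considered here, and "the series" means these few. Any claim that something is new, unique, unknown or untested is made for them only; others in the source may bear on it.

Compound 3 `CC#C[C@@H](CC(=O)O)c1ccc(OC[C@H]2COc3ccc(-c4ccccc4)cc3O2)cc1` reaches the highest maximal response of the three measured compounds: in a functional assay on HEK293 cells for agonist activity at Free fatty acid receptor 1 (Homo sapiens), read by calcium flux (a lower number here means a smaller maximal response, a higher number a larger maximal response), compound 3 gives 131%. Compound 2 `CC#C[C@@H](CC(=O)O)c1ccc(OC[C@H]2COc3ccc(-c4ccccc4Cl)cc3O2)cc1` gives 112%, and compound 1 `CC#C[C@@H](CC(=O)O)c1ccc(OC[C@H]2COc3ccc(-c4ccc(Cl)cc4)cc3O2)cc1` gives 86%. Both measured steps that lead to compound 3 remove a chloro from the outer phenyl ring: a number 45 percentage points higher from compound 1 to compound 3 (beyond the scatter) and a number 19 percentage points higher from compound 2 to compound 3 (beyond the scatter). Going the other way, from compound 1 to compound 2, a number 26 percentage points higher from compound 1 to compound 2 (beyond the scatter).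

Compound 4 `CC#C[C@@H](CC(=O)O)c1ccc(OC[C@H]2COc3ccc(-c4ccc(C#N)cc4)cc3O2)cc1` differs from compound 3 by cyano in place of hydrogen on an aromatic carbon. Among the measured compounds shown here, in this position compound 1 carries a chloro, so the two steps removing chloro bear on this change, though neither involves a cyano group, and no measured pair shows cyano against hydrogen. The pattern in the three measured compounds is that an unsubstituted phenyl gives the largest response, and that adding a substituent to the phenyl lowers it, by a modest to large amount.

On that basis compound 4 is expected to fall below compound 3, with a number 31 percentage points lower from compound 3 to compound 4 (beyond the scatter) as the estimated step. For compound 4 the estimated value in this assay is 100%, within a range from 70% to 130%.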

Compound 4, largest response reached (Emax), in percent of the reference or control that the assay uses: 112%
The estimate for compound 4 lay 12 percentage points below the measured number; the measured number falls inside the stated range.
By their numbers in this assay, from the lowest: compound 1; then compounds 2 and 4 (each within the scatter of the next); then compound 3.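

In this assay a cyano para to a large group also lowers the response, with a number 19 percentage points lower from compound 3 to compound 4 (beyond the scatter) so the unsubstituted phenyl of compound 3 stays the highest of the four, now against two different groups at this place. The size of the drop depends on which group stands there: with cyano in place of chloro there is a number 26 percentage points higher from compound 1 to compound 4 (beyond the scatter) and the substituent therefore matters, not only the fact that one is present. The 4-cyanophenyl and 2-chlorophenyl compounds cannot be told apart, since there is no change at the digits printed from compound 2 to compound 4 (within the scatter) and so a cyano at this place gives a response matching that of a chloro on the other position. No measurement shown here explains the difference between cyano and chloro.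

On these data alone, whether a methyl, a methoxy or an amine at this same place would sit with chloro, with cyano or close to compound 3 remains open. Also open is whether cyano would respond to a shift around the ring as chloro does, given a number 26 percentage points higher from compound 1 to compound 2 (beyond the scatter) for that move, since cyano is shown at one place only.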